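Chloro in Place of Nitro on a Shared Core

The source may hold more compounds than are shown below. What is called first, only, known or untested is meant among the compounds shown, and "the series" means these compounds.

Compound 1 `C/C(=N/NC(=O)Nc1nc(-c2ccc(F)cc2)cc(-c2ccc([N+](=O)[O-])cc2)n1)c1ccc(C)cc1`: in a functional assay on the whole organism (strain Albino) with Mus musculus as the target, with a stated time of 0.5 h (on this read-out lower numbers stand for an effect already at smaller amounts and higher numbers for an effect only at larger amounts of compound), compound 1 gives 100 mg/kg.
Compound 2 `COc1ccc(/C(C)=N\NC(=O)Nc2nc(-c3ccc(F)cc3)cc(-c3ccc([N+](=O)[O-])cc3)n2)cc1`: in this assay compound 2 gives 100 mg/kg.
Compound 3 `C/C(=N/NC(=O)Nc1nc(-c2ccc(C)cc2)cc(-c2ccc(F)cc2)n1)c1ccc([N+](=O)[O-])cc1`: in this assay compound 3 gives 100 mg/kg.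

Compound 3 stands level with compounds 1 and 2, within the scatter. For the measured compounds named here, the single measured step, no change at the digits printed from compound 1 to compound 2 (within the scatter), shows no movement. Compound 4 `C/C(=N/NC(=O)Nc1nc(-c2ccc(C)cc2)cc(-c2ccc(F)cc2)n1)c1ccc(Cl)cc1` differs from compound 3 by chloro in place of nitro on an aromatic carbon. No measured step exchanges a nitro for a chloro, so nothing among these compounds points to a direction for this change, and the one step that exists concerns a different position and is flat. The step expected in this assay is therefore no change at the digits printed from compound 3 to compound 4 (within the scatter), none beyond the scatter. Compound 4 is estimated at 100 mg/kg, with a range from 50 mg/kg to 200 mg/kg.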

Compound 4, dose for half-maximal effect: 30 mg/kg
Compound 4: middle estimate off by 3.3-fold (0.52 log units), on the high side, and the stated range ends above it.
By their numbers in this assay, from the lowest: compound 4; then compounds 1, 2 and 3 (each within the scatter of the next).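

With chloro in place of nitro, this assay gives a 3.3-fold lower number from compound 3 to compound 4 (0.52 log units; beyond the scatter), the only step among these compounds that lies beyond the scatter. This place, para to a large group on the six-membered aromatic ring, therefore responds to the group it carries, which the flat earlier values could not show. Nothing measured on these compounds accounts for the step.

From the compounds shown here alone, it remains open how an amine, a bromo or a carboxylic acid would read at this place. Going by these compounds, whether the same exchange would give a similar step on the 4-nitrophenyl of compound 1 also remains open.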